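Working notes: from compound 3 to compound 4

This account rests on a few compounds, and the source may have more. Where it says the series, first, only, none or still open, it means among the compounds named here.

Going by the values given here, in a functional assay on MDA-MB-231 cells (Homo sapiens) for antiproliferative activity, read by MTT assay, with a stated time of 72 h (on this read-out lower numbers stand for stronger inhibition and higher numbers for weaker inhibition), compound 2 (`Cc1cc(C)cc(OCCCON2C(N)=NC(N)=NC23CCOCC3)c1`) gives 3570 nM, the only number so far. Compound 1 (`COc1ccc(OCCCON2C(N)=NC(N)=NC23CCOCC3)cc1`) stands as "not determined" (no result reported). Compound 3 (`NC1=NC2(CCOCC2)N(OCCCOc2cc(Cl)c(Cl)cc2Cl)C(N)=N1`) stands as "not determined" (no result reported), so it has no position on the numbers. Compound 4 (`NC1=NC2(CCOCC2)N(OCCCOc2cccc(Cl)c2)C(N)=N1`) differs from it in one place: 3-chlorophenyl in place of 2,4,5-trichlorophenyl on an oxygen on a saturated carbon, with 3-chlorophenyl in place of 2,4,5-trichlorophenyl on an oxygen on a saturated carbon. Among the compounds with values here, no step from compound 3 can be sized. Within the data shown here, the only anchor is compound 2 at 3570 nM, and no shift from that value beyond the usual scatter is expected in this assay. Compound 4 is estimated at 3000 nM, with an expected range of 900 nM to 10000 nM.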

Compound 4, half-maximal inhibitory concentration: 1020 nM
For compound 4 the middle estimate is 2.9-fold (0.47 log units) above the measured one; measured number inside the range.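

In this assay, the aryl group on an oxygen on a saturated carbon is shown for the first time to affect the read-out. 3-chlorophenyl in place of 3,5-dimethylphenyl gives a 3.5-fold lower number from compound 2 to compound 4 (0.54 log units; beyond the scatter), a modest step beyond the usual scatter. No evidence bears on the reason for this step.

Steps involving compound 1 or compound 3 cannot be read, so the effect of 2,4,5-trichlorophenyl stays unsized. Also open, on these data alone, is whether an amine or a carboxylic acid on the ring, or a longer chain to the oxygen, would shift the number.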